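This account rests on a few compounds, and the source may have more. Where it says the series, first, only, none or still open, it means among the compounds named here.

Going by the values given here, compound 3 `CC(=O)c1ccc(Nc2nc3nonc3nc2O)cc1` gives, in an assay on mitochondria from L6 cells (Rattus norvegicus) for activation, with a stated time of 90 min (on this read-out lower numbers stand for an effect already at smaller amounts and higher numbers for an effect only at larger amounts of compound), a value of 93700 nM, the highest of the three numbers measured so far. Its nearest neighbour is compound 2 `Oc1nc2nonc2nc1Nc1ccccc1`, which in this assay gives 66700 nM; the step of a 1.4-fold higher number from compound 2 to compound 3 (0.15 log units; within the scatter) is small. Further away stands compound 1 `Oc1nc2nonc2nc1Nc1ccc(OCC(F)(F)F)cc1`, which gives 42300 nM; the step of a 2.2-fold higher number from compound 1 to compound 3 (0.35 log units; beyond the scatter) is a modest one.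

Compound 4 `Oc1nc2nonc2nc1Nc1ccc(OC(F)(F)Cl)cc1` has not yet been measured. It differs from compound 3 in one place: chloro(difluoro)methoxy in place of acetyl on an aromatic carbon. Among the compounds with values here, the only measured step that speaks to this change is a 2.2-fold higher number from compound 1 to compound 3 (0.35 log units; beyond the scatter), where a group of the same kind, 2,2,2-trifluoroethoxy, gave way to acetyl on that aromatic carbon. Putting a halogenated alkoxy group back in place of acetyl is therefore expected to move the number in the opposite direction, by roughly the same modest amount, so compound 4 is estimated at 45000 nM, within 20000 nM to 100000 nM, which would mean a step of a 2.1-fold lower number from compound 3 to compound 4 (0.32 log units; beyond the scatter).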

Compound 4, half-maximal effective concentration: 1900 nM
The estimate for compound 4 lay 24-fold (1.37 log units) above the measured number, and the stated range ends above it.
By their numbers in this assay, from the lowest: compound 4; then compounds 1, 2 and 3 (each within the scatter of the next, the first and the last beyond it).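

Going by these compounds alone, this position can matter far more than the earlier compounds suggested, since their values lay close together. Chloro(difluoro)methoxy in place of acetyl gives (a 49-fold lower number from compound 3 to compound 4 (1.69 log units; beyond the scatter)) in this assay, and the same group in place of hydrogen gives (a 35-fold lower number from compound 2 to compound 4 (1.55 log units; beyond the scatter)). Halogens on the group attached through oxygen are not enough on their own, as chloro(difluoro)methyl in place of 2,2,2-trifluoroethyl still gives (a 22-fold lower number from compound 1 to compound 4 (1.35 log units; beyond the scatter)), and no measurement available here explains this jump.

The compounds shown leave open whether the chlorine is needed, which a comparison with trifluoromethoxy or a plain chlorine on the ring at this place could test. Going by these compounds, it also remains open how an amine or a carboxylic acid at this place would compare.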